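The compounds below may be only part of what the source reports. "The series", "measured", "known", "first", "only" and "open" are said of these compounds alone.

Compound 1, `Cc1nn(CC2(O)COC2)cc1Nc1nc(N)c2c(C#N)c(N3CCC[C@H]3C)n(C)c2n1`, 51 nM
Compound 2, `Cc1nn(C)cc1Nc1nc(N)c2c(C#N)c(N3CCC[C@H]3C)n(C)c2n1`, 30 nM
Compound 3, `C[C@@H]1CCCN1c1[nH]c2ncnc(N)c2c1C#N`, 201 nM

All three were measured in an assay on isolated protein for inhibition of Leucine-rich repeat serine/threonine-protein kinase 2 variant G2019S (Homo sapiens), read by TR-FRET and LanthaScreen, with stated times of 50 min and 30 min, in the presence of a further agent that is not named here; on this read-out higher numbers stand for weaker inhibition and lower numbers for stronger inhibition. Compound 2 shows the lowest of the three numbers, though compound 1 is within the scatter of it, while compound 3 stands beyond it. Compound 4, `C[C@@H]1CCCN1c1c(C#N)c2c(N)nc(Nc3cn(C)nc3Cl)nc2n1C`, has not yet been measured. It differs from compound 2 in one place: chloro in place of methyl on an aromatic carbon. Among the measured compounds shown here, the only measured step, a 1.7-fold lower number from compound 1 to compound 2 (0.23 log units; within the scatter), concerns a saturated chain carbon bound to an aromatic nitrogen, not an aromatic carbon, so no measured step bears directly on this change. With one heavy atom replaced by one heavy atom, no step beyond the scatter is expected. Compound 4 is therefore estimated at 30 nM, with a range from 12 nM to 80 nM, meaning an expected step of no change at the digits printed from compound 2 to compound 4 (within the scatter).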

Compound 4, half-maximal inhibitory concentration: 21 nM
Estimate against measurement, compound 4: 1.4-fold (0.15 log units) above; the range from low to high includes it.
By their numbers in this assay, from the lowest: compounds 4, 2 and 1 (each within the scatter of the next, the first and the last beyond it); then compound 3.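

Chloro and methyl on this aromatic carbon of the five-membered aromatic ring read alike in this assay, with a 1.4-fold lower number from compound 2 to compound 4 (0.15 log units; within the scatter). Among the compounds shown here, the earlier step concerned a saturated chain carbon bound to an aromatic nitrogen, so this is the first reading at this aromatic carbon, and here a chlorine serves as well as a carbon. No evidence is available on what lies behind this match. The compounds shown leave open how trifluoromethyl, methoxy, an amine or plain hydrogen would read on this same carbon.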